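Shortening the nonyl chain and tolerated concentration

A few compounds are considered here, and "the series" means these few. Any claim that something is new, unique, unknown or untested is made for them only; others in the source may bear on it.

Compound 1 `CCCCCCCCCc1cc2cn(COCCO)c(=O)nc2o1`: in a functional assay on HEL cells (Homo sapiens), read by microscopy (a higher number here means that more compound is tolerated, a lower number that less compound is tolerated), compound 1 gives >= 16000 nM, which is a limit of the assay and not a number.
Compound 2 `CCCCCCc1cc2cn(COCCO)c(O)nc-2n1`: in this assay compound 2 gives > 400000 nM, which is again a limit of the assay and not a number.

Among the compounds with values here, compound 1 stands on no exact number in this assay; its value is only a limit, and the one other value shown is also a limit (the limit of > 400000 nM in this assay, at which 1 of the 2 values shown sits). So no measured step between the two compounds can be sized, and of that pair one can say only what its two limits show.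

The account follows the step from compound 1 to compound 3 `CCCCCc1cc2cn(COCCO)c(=O)nc2o1`. The change is hydrogen in place of butyl on a saturated chain carbon, five bonds along the chain from an aromatic carbon. Since compound 1 sits at a limit (the limit of >= 16000 nM in this assay, at which 1 of the 2 values shown sits), the step in this assay is expected to run toward a higher number, or to stay within the scatter. Compound 3 is therefore expected to give about 40000 nM, with a range from 12000 nM to 200000 nM, meaning an expected step that the limit leaves unreadable from compound 1 to compound 3.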

Compound 3, minimum cytotoxic concentration: > 400000 nM
Compound 3: a limit, no number (the forecaster's own chance of this, stated with the estimate: 70%); middle value at least 10-fold (1.00 log units) from the limit.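

In this assay compound 3 gives > 400000 nM, a limit of the assay and not a number. Within the data shown here, compound 1 also rests on a limit, so no step between compound 1 and compound 3 can be read. The compounds shown leave open how much replacing butyl with hydrogen changes the tolerated concentration.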